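Acetylation of a Hydroxy Group in a Weakly Cytotoxic Series

The compounds below may be only part of what the source reports. "The series", "measured", "known", "first", "only" and "open" are said of these compounds alone.

compound 1, `COc1ccc(C(=O)O[C@H]2CC(C)=C[C@@H](OC(C)=O)[C@@]3(C)[C@@H](OC(C)=O)C[C@@](O)(C(C)C)[C@H]23)cc1`: > 100000 nM
compound 2, `COc1ccc(C(=O)O[C@H]2CC(C)=C[C@H](OC(C)=O)[C@]3(C)[C@@H]2[C@](O)(C(C)C)C[C@@H]3O)cc1`: 70400 nM

Among the compounds with values here, in a functional assay on K562 cells (Homo sapiens) for cytotoxicity, read by MTT assay, with a stated time of 72 h (a higher number here means a weaker inhibitor, a lower number a stronger inhibitor), compound 2 gives 70400 nM, the only number in the set. For compound 1 the reading is a limit of the assay, > 100000 nM, which is the limit of > 100000 nM in this assay, at which 1 of the 2 values shown sits. Compound 3, `COc1ccc(C(=O)O[C@H]2CC(C)=C[C@H](OC(C)=O)[C@@]3(C)[C@@H](OC(C)=O)C[C@@](O)(C(C)C)[C@H]23)cc1`, differs from compound 2 by acetyl in place of hydrogen on an oxygen on a saturated carbon. No step between measured compounds is shown, so there is no basis for a change beyond the scatter in either direction. The step of a 1.4-fold higher number from compound 2 to compound 3 (0.15 log units; within the scatter) is therefore expected to be small. Compound 3 is estimated at 100000 nM, with a range from 30000 nM to 300000 nM, and a limit reading would not be surprising.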

Compound 3, half-maximal inhibitory concentration: 39600 nM
Compound 3: the middle estimate sits 2.5-fold (0.40 log units) above what was measured; low and high end bracket the measured number.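

In this assay, acetyl in place of hydrogen on an oxygen on a saturated carbon gives a 1.8-fold lower number from compound 2 to compound 3 (0.25 log units; within the scatter), so hydroxy to acetoxy does not separate the two compounds. A change of configuration at a saturated ring carbon gives an at least 2.5-fold lower number from compound 1 to compound 3 (0.40 log units; beyond the scatter), and what separates this pair is stated plainly: the fact that compounds 1 and 3 differ only in the configuration as drawn. That step rests on a reading for compound 1 that is a limit, not a number: the limit of > 100000 nM in this assay, at which 1 of the 3 values shown sits. On these data alone, whether a butyryl chain or an amine at this oxygen would shift the reading remains open, as does the effect of acetyl there under the other configuration.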